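Replacing the Chlorophenyl on the Ester Chain of Compound 3

The source may hold more compounds than are shown below. What is called first, only, known or untested is meant among the compounds shown, and "the series" means these compounds.

Of the compounds shown here, three built on a shared core have been measured in an assay on thoracic aorta for inhibition of Voltage-gated L-type calcium channel (Rattus norvegicus); on this read-out lower numbers stand for stronger inhibition and higher numbers for weaker inhibition. Compound 1 `CC1=C(C(=O)O)C(c2cccc(Cl)c2)C(C(=O)OC/C=C/c2ccccc2)=C(C#N)N1` gives 2000 nM. Compound 2 `COC(OC)C1=C(C(=O)O)C(c2cccc(Cl)c2)C(C(=O)OC/C=C/c2ccccc2)=C(C)N1` gives 1300 nM. Compound 3 `COC(OC)C1=C(C(=O)OC/C=C/c2cccc(Cl)c2)C(c2cccc(Cl)c2)C(C(=O)O)=C(C)N1` gives 1000 nM, the lowest of the three numbers, though its gap to compound 2 and its gap to compound 1 both lie within the usual scatter of this assay, so no order among the three can be read from these values.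

Compound 4 `COc1ccccc1/C=C/COC(=O)C1=C(C(OC)OC)NC(C)=C(C(=O)O)C1c1cccc(Cl)c1` differs from compound 3 in one place: 2-methoxyphenyl in place of 3-chlorophenyl on a double-bonded chain carbon bound to a double-bonded chain carbon. Within the data shown here, no pair of measured compounds differs in exactly this way, so there is no measured step to lean on. What the three measured values do show is that changes elsewhere on this core have left this assay nearly unchanged, all three numbers sitting close together, and the present change touches only the aromatic ring at the end of the ester chain while the rest of the molecule stays as in compound 3. The expected step is a 1.3-fold higher number from compound 3 to compound 4 (0.11 log units; within the scatter), that is, nothing beyond the scatter in either direction. Compound 4 is therefore estimated at 1300 nM, within a range of 500 nM to 3500 nM.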

Compound 4, half-maximal inhibitory concentration: 5900 nM
The estimate for compound 4 lay 4.5-fold (0.66 log units) below the measured number; measured number outside the range, above it.
By their numbers in this assay, from the lowest: compounds 3, 2 and 1 (each within the scatter of the next); then compound 4.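

Exchanging 3-chlorophenyl for 2-methoxyphenyl, on a double-bonded chain carbon bound to a double-bonded chain carbon, produces in this assay a 5.9-fold higher number from compound 3 to compound 4 (0.77 log units; beyond the scatter), a step that stands beyond the scatter. The earlier compounds shown here offered no measured step between neighbours, and their close values could not show whether any single place on the shared core mattered; this pair shows that the read-out does respond to the aromatic ring at the end of the ester chain, and that this ring cannot be exchanged freely without the number moving towards weaker inhibition. The compounds shown hold no measurement that bears on what lies behind this step.

The step joins two differences, the kind of group on the ring and its place in the group's name, and the pair cannot separate them: 3-methoxyphenyl or 2-chlorophenyl at the same place on the chain would divide the two. Compounds 1 and 2 carry a plain phenyl on their ester chain but differ from compound 3 and compound 4 in more than one place, so they cannot say how that ring alone would read.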